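The compounds below may be only part of what the source reports. "The series", "measured", "known", "first", "only" and "open" are said of these compounds alone.

Measured compounds:
compound 1, `NS(=O)(=O)Oc1ccc2c(c1)CN(C(=O)c1ccc(N(Cc3ccccc3)Cc3ccco3)cc1)CC2`: 98.2%
compound 2, `NS(=O)(=O)Oc1ccc2c(c1)CN(C(=O)c1ccc(N3CCC(N4CCCCC4)CC3)cc1)CC2`: 53.7%

Both compounds were tested in an assay on HEK293 cells for inhibition of Steryl-sulfatase (Homo sapiens), tested at 1 uM; on this read-out lower numbers stand for a weaker effect and higher numbers for a stronger effect at the one concentration tested. Compound 1 gives 98.2%, the higher of the two numbers. Compound 2, which carries a different amine on the shared core, gives 53.7%, and the gap between the two lies beyond the scatter. Within the data shown here, no pair of measured compounds differs in a single place, so no measured step is available to guide the next comparison.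

Compound 3, `CN(C)CCCN(Cc1ccccc1)c1ccc(C(=O)N2CCc3ccc(OS(N)(=O)=O)cc3C2)cc1`, has not yet been measured. It differs from compound 1 in one place: 2-(dimethylamino)ethyl in place of furan-2-yl on a saturated chain carbon bound to a nitrogen on an aromatic ring. The benzyl group and the remainder of the core are unchanged. Compound 2 shows that a different amine on the core can lower the read-out well beyond the scatter, yet compound 3 keeps more of compound 1 than compound 2 does. In this assay the expected step is a small decrease, likely within the scatter or just beyond it: a number 13.2 percentage points lower from compound 1 to compound 3 (beyond the scatter). Compound 3 is therefore estimated at 85%, with a range from 55% to 98%.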

Compound 3, a percentage reported as inhibition, at one concentration (the size of the read-out at that concentration, not a potency): 61.6%
The estimate for compound 3 lay 23.4 percentage points above the measured number, and the stated range covers the measured number.
By their numbers in this assay, from the lowest: compounds 2 and 3 (each within the scatter of the next); then compound 1.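

In this assay, among these compounds, 2-(dimethylamino)ethyl in place of furan-2-yl on a saturated chain carbon bound to a nitrogen on an aromatic ring gives a number 36.6 percentage points lower from compound 1 to compound 3 (beyond the scatter), the first step in one place, and it shows that the read-out depends on which group stands at this position while the benzyl group and the core stay fixed. The two groups have the same counts of heavy atoms, hydrogen-bond donors and hydrogen-bond acceptors, and neither carries a net charge, so those counts do not separate them; what does differ is that furan-2-yl is a five-membered aromatic ring holding an oxygen, whereas 2-(dimethylamino)ethyl has no ring and holds a nitrogen. Nothing available explains why the number falls with this change.

This single step changes the ring and the hetero atom together, so the compounds shown cannot say which of the two accounts for the fall. A tetrahydrofuran-2-yl group or a phenyl ring at the same position would pull these apart, while a plain butyl chain would show how an open chain without an amine reads.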